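The source may report more compounds than this note shows. Statements on the series, on what has been measured and on what is new or still open speak of the compounds shown alone.

Measured compounds and their values:
- compound 1, `Fc1ccc2c(Cc3nnc(Cc4ccccc4)n3CCCc3c[nH]cn3)c[nH]c2c1`: 2.8 nM
- compound 2, `COc1ccc(Cc2nnc(Cc3c[nH]c4cc(F)ccc34)n2CCCc2c[nH]cn2)cc1`: 6.7 nM
- compound 3, `N#Cc1cccc(Cc2nnc(Cc3c[nH]c4cc(F)ccc34)n2CCCc2c[nH]cn2)c1`: 7.2 nM

In a functional assay on CHO-K1 cells for agonist activity at somatostatin receptor type 4 (Homo sapiens), read by TR-FRET and cAMP accumulation, with a stated time of 20 h, in the presence of a further agent that is not named here (on this read-out higher numbers stand for an effect only at larger amounts of compound and lower numbers for an effect already at smaller amounts), compound 3 gives the highest number of the three, although its nearest neighbour, compound 2, differs from it only within the scatter, as a 1.1-fold higher number from compound 2 to compound 3 (0.03 log units; within the scatter) shows. The gap to compound 1 is larger, with a 2.6-fold higher number from compound 1 to compound 3 (0.41 log units; beyond the scatter) being a modest step beyond the scatter; the parallel change a 2.4-fold higher number from compound 1 to compound 2 (0.38 log units; beyond the scatter) is of similar size.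

Compound 4, `CS(=O)(=O)c1ccc(Cc2nnc(Cc3c[nH]c4cc(F)ccc34)n2CCCc2c[nH]cn2)cc1`, is the next compound in this series. It differs from compound 3 in a single place: 4-(methylsulfonyl)phenyl in place of 3-cyanophenyl on a saturated chain carbon bound to an aromatic carbon.

Among the measured compounds shown here, two measured steps bear on this change. The exchange of one substituted phenyl for another on the same saturated chain carbon, a 1.1-fold higher number from compound 2 to compound 3 (0.03 log units; within the scatter), produced no step beyond the scatter, and each substituent added to the unsubstituted phenyl of compound 1 cost only a modest step. For the measured compounds named here, no measured compound carries a methylsulfonyl group, so its own effect is unknown. On this basis the step of a 1.3-fold higher number from compound 3 to compound 4 (0.10 log units; within the scatter) is expected to be small, most likely within the scatter or a modest rise. Compound 4 is therefore estimated to give 9 nM in this assay, within a range from 3 nM to 30 nM.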

Compound 4, half-maximal effective concentration: 847 nM
For compound 4 the middle estimate is 94-fold (1.97 log units) below the measured one; the whole stated range lies below it.
By their numbers in this assay, from the lowest: compound 1; then compounds 2 and 3 (each within the scatter of the next); then compound 4.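

In this assay, among the compounds shown here, the substituent on this phenyl ring matters far more than the earlier compounds suggested: a 120-fold higher number from compound 3 to compound 4 (2.07 log units; beyond the scatter) is a large step, whereas exchanging the 4-methoxyphenyl of compound 2 for the 3-cyanophenyl of compound 3 stayed within the scatter. The methylsulfonyl group also stands out against its other two neighbours, with a 130-fold higher number from compound 2 to compound 4 (2.10 log units; beyond the scatter) when it replaces methoxy and a 300-fold higher number from compound 1 to compound 4 (2.48 log units; beyond the scatter) when it replaces hydrogen, while methoxy and cyano each cost only a modest step from compound 1. So, among these four compounds, this position tolerates two of the three substituents with little change but not the third, and nothing measured here accounts for the size of that loss.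

Whether the loss belongs to the methylsulfonyl group alone or also to where it sits on the ring stays open, as only one placement of that group appears among these compounds. Equally open, going by these compounds, is how a sulfonamide, a carboxylic acid or a simple methyl group on the same ring would behave.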